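Swapping Piperidine for Piperazine on the Shared Core

The source may report more compounds than this note shows. Statements on the series, on what has been measured and on what is new or still open speak of the compounds shown alone.

- Compound 1 `O=C(Nc1ccnnc1)c1cc(N2CCCCC2)ccc1OCc1ccccc1`: 60000 nM
- Compound 2 `O=C(Nc1cccnc1)c1cc(C(F)(F)F)ccc1OCc1ccccc1`: < 1000 nM (a limit)

For the measured compounds named here, in a physicochemical assay for solubility, measured as kinetic solubility (a higher number here means a more soluble compound, a lower number a less soluble compound), compound 1 gives 60000 nM, the only exact number so far. Compound 2 gives < 1000 nM, which is a limit and not an exact number. Compound 3 `O=C(Nc1ccnnc1)c1cc(N2CCNCC2)ccc1OCc1ccccc1` carries piperazin-1-yl in place of piperidin-1-yl on an aromatic carbon. Going by the values given here, no measured pair differs in one place only, so the size of this step is a judgement. A small upward step, close to the usual scatter of this assay, is expected, estimated as a 1.7-fold higher number from compound 1 to compound 3 (0.22 log units; within the scatter). Compound 3 is expected at 100000 nM, with an estimated range of 40000 nM to 200000 nM.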

Compound 3, solubility: 98000 nM
Compound 3: middle estimate off by 1.0-fold (0.01 log units), on the high side; the range from low to high includes it.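

For the compounds shown here, the swap of piperidin-1-yl for piperazin-1-yl at this position is the first single change that can be read in this assay, and it gives a 1.6-fold higher number from compound 1 to compound 3 (0.21 log units; within the scatter). The two compounds therefore cannot be told apart, even though the entering ring brings a second nitrogen and a hydrogen-bond donor. Nothing shown here bears on why.

From the compounds shown here alone, it remains open whether morpholin-4-yl, an open-chain amine or a carboxylic acid at this position would read any differently. Going by these compounds, whether the same swap would read alike on another core also remains open.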